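The compounds below may be only part of what the source reports. "The series", "measured", "known", "first", "only" and "open" are said of these compounds alone.

Working notes on the series. In a physicochemical assay for solubility (on this read-out higher numbers stand for higher solubility and lower numbers for lower solubility), compound 1 `CNC(=O)c1cc(C(=O)NC2CC2)cn(Cc2ccc(F)cc2)c1=O` gives >= 162 ug/mL, which is a limit of the assay and not a number. In the same read-out compound 2 `CNC(=O)c1cc(C(=O)NCCC2CCOCC2)cn(Cc2ccccc2)c1=O` gives >= 127 ug/mL, also a limit. Going by the values given here, compound 1 is therefore placed only by a limit, and no measured step connects it to another compound. Compound 3 `CNC(=O)c1cc(C(=O)NC2CC2)cn(Cc2cccc3[nH]ccc23)c1=O` differs from compound 1 at one place: 1H-indol-4-yl in place of 4-fluorophenyl on a saturated chain carbon bound to an aromatic nitrogen. In words, this is 1H-indol-4-yl in place of 4-fluorophenyl on a saturated chain carbon bound to an aromatic nitrogen. Among the compounds with values here, with no measured step to draw on, a moderate fall in this assay is expected, as a judgement only. The expected change is an at least 2.3-fold lower number from compound 1 to compound 3 (0.36 log units; beyond the scatter). For compound 3 the estimated value is 70 ug/mL, with an expected range of 25 ug/mL to 170 ug/mL.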

Compound 3, solubility: 78 ug/mL
Compound 3: middle estimate off by 1.1-fold (0.05 log units), on the low side, within the range that was stated.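

Working notes, continued. Placing 1H-indol-4-yl in place of 4-fluorophenyl on a saturated chain carbon bound to an aromatic nitrogen gives an at least 2.0-fold lower number from compound 1 to compound 3 (0.31 log units; beyond the scatter) in this assay, the first measured sign that the group at this place bears on the read-out. Compound 3 is the only compound shown with a number rather than a limit, so the series now has one firm point. The full size of the step cannot be read because compound 1 is placed only by a limit of the assay and not a number: the limit of >= 162 ug/mL in this assay, at which 1 of the 3 values shown sits.

On these data alone, whether the lower number goes with the hydrogen-bond donor of 1H-indol-4-yl or with its second ring stays open, as does how an amine or a carboxylic acid would read at this place. Compound 2 differs from compound 1 and compound 3 in more than one place, so it cannot settle either question.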